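Compound 3: one aryl swap on a nitrogen

This account rests on a few compounds, and the source may have more. Where it says the series, first, only, none or still open, it means among the compounds named here.

compound 1 `COc1ccc(Nc2nnc(Cl)c(Nc3cc(OC)c(OC)c(OC)c3)n2)cc1` with 19000 nM
compound 2 `COc1cc(Nc2nc(Nc3ccc4c(ccn4C)c3)nnc2Cl)cc(OC)c1OC` with 28100 nM

Among the compounds with values here, in a functional assay on MGC-803 cells (Homo sapiens) for inhibition, read by MTT assay, with a stated time of 48 h (a lower number here means a stronger inhibitor, a higher number a weaker inhibitor), compound 2 gives 28100 nM and so sits within the scatter of compound 1, the only other measured compound. Compound 3 `COc1cc(Nc2nc(Nc3ccc(C(C)=O)cc3)nnc2Cl)cc(OC)c1OC` differs at one place, with 4-acetylphenyl in place of 1-methyl-1H-indol-5-yl on a nitrogen on an aromatic ring. Within the data shown here, the only measured step at that place (a 1.5-fold higher number from compound 1 to compound 2 (0.17 log units; within the scatter)) stayed within the scatter, so no step beyond the scatter is expected in this assay here, although 4-acetylphenyl itself is untested. The expected step is small (a 1.4-fold lower number from compound 2 to compound 3 (0.15 log units; within the scatter)). Compound 3 is estimated at 20000 nM (expected range 7000 nM to 50000 nM).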

Compound 3, half-maximal inhibitory concentration: 13000 nM
Beside the measured number, compound 3's estimate is 1.5-fold (0.19 log units) above it, and the stated range covers the measured number.
By their numbers in this assay, from the lowest: compounds 3, 1 and 2 (each within the scatter of the next, the first and the last beyond it).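

On this nitrogen, swapping the 1-methyl-1H-indol-5-yl group for 4-acetylphenyl gives a modest change in this assay (a 2.2-fold lower number from compound 2 to compound 3 (0.33 log units; beyond the scatter)), so unlike the earlier step, this one does move the number past the scatter. Acetyl in place of methoxy on an aromatic carbon shows no such separation (a 1.5-fold lower number from compound 1 to compound 3 (0.16 log units; within the scatter)), so the two phenyl groups cannot be told apart here. Nothing available explains the step from the indole to the acetylphenyl group. Going by these compounds, it remains open whether an amine or a carboxylic acid in place of the acetyl would give a larger step.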